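Aryl swap on the hydrazone of a diisobutyl analogue

The source may report more compounds than this note shows. Statements on the series, on what has been measured and on what is new or still open speak of the compounds shown alone.

In an assay on HeLa cells for inhibition of Indoleamine 2,3-dioxygenase 1 (Homo sapiens), with a stated time of 24 h (a higher number here means a weaker inhibitor, a lower number a stronger inhibitor), three compounds of one series have been measured. Among the compounds with values here, compound 1 `CCCCN(CCCC)c1ccc(/C(C)=C/C(=O)O)cc1NC(=O)N/N=C/c1ccc(Cl)cc1` gives 3870 nM and compound 2 `CCCCN(CCCC)c1ccc(/C(C)=C/C(=O)O)cc1NC(=O)N/N=C/c1ccccc1C(F)(F)F` gives 2830 nM; the only single-point step among them, a 1.4-fold lower number from compound 1 to compound 2 (0.14 log units; within the scatter), lies within the scatter. Compound 3 `C/C(=C\C(=O)O)c1ccc(N(CC(C)C)CC(C)C)c(NC(=O)N/N=C/c2ccccc2F)c1` gives 1950 nM, the lowest of the three numbers, though its gaps to compound 2 and to compound 1 are both within the scatter, so no order can be read from them.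

Compound 4 `C/C(=C\C(=O)O)c1ccc(N(CC(C)C)CC(C)C)c(NC(=O)N/N=C/c2ccc(Cl)cc2)c1` has not been measured. It differs from compound 3 in one place: 4-chlorophenyl in place of 2-fluorophenyl on a carbon with a double bond to nitrogen. Within the data shown here, no measured step covers this exact exchange. Among the measured compounds shown here, the one step that touches the same position, a 1.4-fold lower number from compound 1 to compound 2 (0.14 log units; within the scatter), stayed within the scatter, and the numbers of compound 1 and compound 3, which share neither the aryl group nor the alkyl groups, differ by only a little more. The step of a 1.4-fold higher number from compound 3 to compound 4 (0.16 log units; within the scatter) is therefore expected to stay within the scatter. Compound 4 is estimated at 2800 nM, within 1400 nM to 5600 nM.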

Compound 4, half-maximal inhibitory concentration: 1020 nM
Compound 4: middle estimate off by 2.7-fold (0.44 log units), on the high side, and the stated range ends above it.
By their numbers in this assay, from the lowest: compounds 4, 3, 2 and 1 (each within the scatter of the next, the first and the last beyond it).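

In this assay, 4-chlorophenyl in place of 2-fluorophenyl on a carbon with a double bond to nitrogen gave a 1.9-fold lower number from compound 3 to compound 4 (0.28 log units; within the scatter) and so, like the earlier exchange at this position, produced no change that can be told from the scatter. Within the data shown here, the only step beyond the scatter lies elsewhere: with 4-chlorophenyl held constant, diisobutylamino in place of dibutylamino on an aromatic carbon gave a 3.8-fold lower number from compound 1 to compound 4 (0.58 log units; beyond the scatter) in a modest step. Nothing at hand bears on the reason for either step.

On these data alone, the amine exchange rests on this single pair, so whether it holds with 2-fluorophenyl or 2-(trifluoromethyl)phenyl remains open. Also open, as far as these compounds go, is how a shorter chain such as dipropylamino, or a piperidine, would read at that place, and how a pyridine would read on the hydrazone.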